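Moving the acetyl group, then trimming it to formyl

The source may report more compounds than this note shows. Statements on the series, on what has been measured and on what is new or still open speak of the compounds shown alone.

A set of compounds on one shared core was tested in a functional assay on MV4-11 cells (Homo sapiens) for inhibition, read by resazurin assay, with a stated time of 72 h; a higher number here means a weaker inhibitor of growth, a lower number a stronger inhibitor of growth. Compound 1 `CC(=O)c1ccc(-c2cncc(Cl)c2N2CCC3(CCNC3=O)CC2)s1` gives 1440 nM. Compound 2 `O=Cc1ccc(-c2cncc(Cl)c2N2CCC3(CCNC3=O)CC2)s1` gives 750 nM. The change between them is hydrogen in place of methyl on a carbonyl carbon, and it made a step of a 1.9-fold lower number from compound 1 to compound 2 (0.28 log units; within the scatter). Compound 3 `CC(=O)c1sccc1-c1cncc(Cl)c1N1CCC2(CCNC2=O)CC1` has the same atoms joined differently, the difference being (2-acetylthiophen-3-yl in place of 5-acetylthiophen-2-yl on an aromatic carbon). In this assay compound 3 reaches only a limit, > 100000 nM. The steps of an at least 69-fold higher number from compound 1 to compound 3 (1.84 log units; beyond the scatter) and an at least 130-fold higher number from compound 2 to compound 3 (2.12 log units; beyond the scatter) are accordingly both large. Compound 4 `O=Cc1sccc1-c1cncc(Cl)c1N1CCC2(CCNC2=O)CC1` is not yet measured; it differs from compound 3 by hydrogen in place of methyl on a carbonyl carbon. The surroundings of the carbonyl carbon are the same in both changes, so this is the same change as from compound 1 to compound 2, made on the other core. Compound 3 already sits at the limit (the limit of > 100000 nM in this assay, at which 1 of the 3 values shown sits), and the earlier step of a 1.9-fold lower number from compound 1 to compound 2 (0.28 log units; within the scatter) stayed within the scatter. On that basis compound 4 is expected to make a step of a number no higher from compound 3 to compound 4 (the limit leaves the size open), most likely ending again at a limit. The estimate for compound 4 is 100000 nM, between 30000 nM and 300000 nM.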

Compound 4, concentration for 50% growth inhibition: 28700 nM
Beside the measured number, compound 4's estimate is 3.5-fold (0.54 log units) above it; measured number outside the range, below it.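

In this assay the value of compound 3, > 100000 nM, is a limit and not a number. Carried to the second core, the change from acetyl to formyl gives an at least 3.4-fold lower number from compound 3 to compound 4 (0.54 log units; beyond the scatter), yet compound 4 remains far from the compounds that carry their group as a 5-substituted thiophen-2-yl, with a 38-fold higher number from compound 2 to compound 4 (1.58 log units; beyond the scatter) and a 20-fold higher number from compound 1 to compound 4 (1.30 log units; beyond the scatter), so the change does not close the gap between the two arrangements. This is one pair of cores only, and it cannot say whether the change acts alike on both: the same change on two cores in this assay, a 1.9-fold lower number (0.28 log units; within the scatter) from compound 1 to compound 2 and an at least 3.4-fold lower number (0.54 log units; beyond the scatter) from compound 3 to compound 4; the limit leaves it open whether they differ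

The compounds shown leave open what a carboxylic acid or a longer chain such as propanoyl would do in place of the acetyl or formyl group on either core. They also leave open whether an amine there, such as aminomethyl, would follow the same course as the change from acetyl to formyl.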